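Removing the benzyl arm: what cytotoxicity to expect

A few compounds are considered here, and "the series" means these few. Any claim that something is new, unique, unknown or untested is made for them only; others in the source may bear on it.

Compound 1 `CCC1(Cc2ccccc2)OS(=O)(=O)C=C1OCc1ccccc1` is the reference point of this small series. In an ADME assay on HEL cells (Homo sapiens) for cytotoxicity, with a stated time of 3 days (on this read-out lower numbers stand for higher toxicity in this test and higher numbers for lower toxicity in this test), compound 1 gives only a limit, >= 50000 nM. Its two neighbours are likewise known only as limits. Compound 2 `CCC1(Cc2ccccc2)OS(=O)(=O)C=C1OCc1ccc([N+](=O)[O-])cc1` gives a limit of >= 80000 nM in this assay. Compound 3 `CCC1(Cc2ccccc2)OS(=O)(=O)C=C1OCc1ccc(C)cc1` gives a limit of >= 16000 nM in this assay. The steps a step that the two limits leave unreadable from compound 1 to compound 2, a step that the two limits leave unreadable from compound 1 to compound 3 and a step that the two limits leave unreadable from compound 2 to compound 3 therefore remain unreadable, as the limits (the limit of >= 16000 nM in this assay, at which 1 of the 3 values shown sits), the limit of >= 50000 nM in this assay, at which 1 of the 3 values shown sits, and the limit of >= 80000 nM in this assay, at which 1 of the 3 values shown sits, show.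

Compound 4 `CCC1(CC)OS(=O)(=O)C=C1OCc1ccccc1` differs from compound 1 in one place: methyl in place of phenyl on a saturated chain carbon bound to a saturated ring carbon. Going by the values given here, no measured step touches that place; the three measured steps all sit on an aromatic carbon. With every value a limit and no readable step, the expectation for compound 4 is no change beyond the scatter, so the step from compound 1 to compound 4 is estimated as a number no higher from compound 1 to compound 4 (the limit leaves the size open). Compound 4 is therefore expected to give about 50000 nM, within 16000 nM to 100000 nM, most likely again reported only as a limit.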

Compound 4, minimum cytotoxic concentration: > 400000 nM
Compound 4: no number, only a limit; the forecaster's own chance of this, stated with the estimate: 80%; at least 8.0-fold (0.90 log units) between middle value and limit.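

In this assay compound 4 gives only a limit, > 400000 nM. Compound 1 is also known only as a limit, so no step can be read between compound 1 and compound 4. The compounds shown leave open whether benzyl to ethyl changes the read-out, and by how much.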